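A few compounds are considered here, and "the series" means these few. Any claim that something is new, unique, unknown or untested is made for them only; others in the source may bear on it.

In a physicochemical assay for solubility, in simulated intestinal fluid, at pH 7.4 (on this read-out lower numbers stand for lower solubility and higher numbers for higher solubility), compound 1 (`Cn1nc(C(=O)Nc2ccc(-c3ccccc3)c(C(F)(F)F)c2)c(=O)c2ccccc21`) gives 12 ug/mL, compound 2 (`Cn1cc(C(=O)Nc2cnc(-c3ccccc3)c(C(F)(F)F)c2)c(=O)c2ccccc21`) gives 13 ug/mL and compound 3 (`Cn1cc(C(=O)Nc2ccc(-c3ccccc3)c(C(F)(F)F)c2)c(=O)c2ccccc21`) gives 11 ug/mL. These three numbers lie within the usual scatter of one another, so compound 3 stands level with the other two, and no ranking can be read from them.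

Compound 4 (`Cn1cc(C(=O)Nc2ccc(-c3cccnc3)c(C(F)(F)F)c2)c(=O)c2ccccc21`) is compound 3 with a single change: pyridin-3-yl in place of phenyl on an aromatic carbon, ortho to a trifluoromethyl group and para to a large group (pyridin-3-yl in place of phenyl on an aromatic carbon). Going by the values given here, no two measured compounds differ in just one place, so the data offer no direct guide to this swap. The expectation is therefore cautious: a small upward step in this assay, close in size to the scatter, and a result inside the scatter would be no surprise. The estimated step is a 1.6-fold higher number from compound 3 to compound 4 (0.21 log units; within the scatter). For compound 4 the estimate is 18 ug/mL, with an expected range from 7 ug/mL to 45 ug/mL.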

Compound 4, solubility: 6.7 ug/mL
Beside the measured number, compound 4's estimate is 2.7-fold (0.43 log units) above it, and the stated range ends above it.
By their numbers in this assay, from the lowest: compounds 4, 3, 1 and 2 (each within the scatter of the next).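

In this assay, putting pyridin-3-yl in place of phenyl at this position gives a 1.6-fold lower number from compound 3 to compound 4 (0.22 log units; within the scatter) and that step lies within the usual scatter of repeated measurements. This is the first pair shown that differs in one place only, and it shows that this swap, which brings in one ring nitrogen and one hydrogen-bond acceptor, leaves no change that this assay can separate from the scatter. Nothing measured here offers a reason for the result.

Still open, on these data alone, is whether a group of another kind on this aromatic carbon, such as an amine or a carboxylic acid on the ring, would take the number beyond the scatter. As far as these compounds go, whether pyridin-3-yl would give a similar step on the cores of compound 1 or compound 2 also stays open.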